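The compounds below may be only part of what the source reports. "The series", "measured", "known", "first", "only" and "open" are said of these compounds alone.

In an ADME assay on microsomes from liver (Rattus norvegicus) for metabolic stability, read by LC-MS, with a stated time of 30 min, tested at 0.1 uM (on this read-out higher numbers stand for a more stable compound and lower numbers for a less stable compound), compound 2 (`COc1ccnc(Nc2cc3[nH]c(-c4cccc(C(F)(F)F)c4)nc3cn2)c1`) gives 71%. Compound 3 (`Fc1ccc(-c2nc3cnc(Nc4ccccn4)cc3[nH]2)cc1C(F)(F)F`) gives 67% and compound 1 (`FC(F)(F)Oc1ccc(-c2nc3cnc(Nc4ccccn4)cc3[nH]2)cc1`) gives 61%. Both lie within the usual scatter of compound 2, so these three measurements do not separate the compounds.

The next compound to be read is compound 4 (`Fc1cnc(Nc2cc3[nH]c(-c4cccc(C(F)(F)F)c4)nc3cn2)c(F)c1`). It carries 3,5-difluoropyridin-2-yl in place of 4-methoxypyridin-2-yl on a nitrogen on an aromatic ring, a difference counted as follows: 3,5-difluoropyridin-2-yl in place of 4-methoxypyridin-2-yl on a nitrogen on an aromatic ring.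

Within the data shown here, no measured pair in this set differs in one place only, so the data contain no direct precedent for the size or direction of this exchange. The expectation rests only on the three values in hand, which remain within the scatter of compound 2 even though the compounds differ in more than one place. The estimated change is small, with no firm direction and nothing expected beyond the scatter: a number 3 percentage points lower from compound 2 to compound 4 (within the scatter).

Among the measured compounds shown here, the uncertainty stays wide, as no measured compound carries the entering group. In this assay, the expected value for compound 4 is 68%, with an estimated range of 52% to 82%.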

Compound 4, percent of the compound remaining: 43%
Beside the measured number, compound 4's estimate is 25 percentage points above it; measured number below the stated range.
By their numbers in this assay, from the lowest: compound 4; then compounds 1, 3 and 2 (each within the scatter of the next).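

Among these compounds, the exchange on a nitrogen on an aromatic ring gives the first single-place comparison: in this assay, the step is a number 28 percentage points lower from compound 2 to compound 4 (beyond the scatter), so this position is not indifferent to the group it carries. The leaving 4-methoxypyridin-2-yl and the entering 3,5-difluoropyridin-2-yl have the same heavy-atom count and the same type of ring, so a step of this size can occur with both of those counts unchanged. No measurement in hand bears on what lies behind the step, which therefore stays unexplained.

The compounds shown leave open whether the step needs both fluorines of the entering group, or whether a pyridine ring carrying a single fluorine, a nitrile or an amine at this place would read closer to compound 2 or to compound 4. They also leave open whether the same exchange gives a step of similar size when the other end of the molecule carries the aryl group of compound 1 or of compound 3.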